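The source may report more compounds than this note shows. Statements on the series, on what has been measured and on what is new or still open speak of the compounds shown alone.

Of the compounds shown here, three have been measured so far in a functional assay on U-251 cells (Homo sapiens) for inhibition, read by sulforhodamine B assay, with a stated time of 48 h (a higher number here means a weaker inhibitor of growth, a lower number a stronger inhibitor of growth), and a fourth has not. Compound 1 `COc1ccc(-c2cc(/C=C/C(=O)c3ccc(N)cc3)[nH]n2)cc1` gives 2570 nM in this assay. Compound 2 `COc1ccc(C(=O)/C=C/c2cc(-c3cc(OC)c(OC)c(OC)c3)n[nH]2)cc1OC` gives 2480 nM in this assay. Compound 3 `COc1ccc(-c2cc(/C=C/C(=O)c3ccc(N)cc3)[nH]n2)cc1OC` gives 3660 nM in this assay. The two values of compound 1 and compound 2 sit within the scatter of each other, and the difference between their two cores is not broken down here.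

Compound 3 arises from compound 1 by one change, (methoxy in place of hydrogen on an aromatic carbon), and the step of a 1.4-fold higher number from compound 1 to compound 3 (0.15 log units; within the scatter) is within the scatter, so this change left the number essentially where it was.

Compound 4 `COc1cc(C(=O)/C=C/c2cc(-c3cc(OC)c(OC)c(OC)c3)n[nH]2)cc(OC)c1OC` is still to be measured. It arises from compound 2 by methoxy in place of hydrogen on an aromatic carbon. Among the measured compounds shown here, this is the same kind of change as the one from compound 1 to compound 3, though the surroundings are not identical: in compound 4 the entering methoxy is also meta to a methoxy group, which is not the case in compound 3.

Because the earlier step of a 1.4-fold higher number from compound 1 to compound 3 (0.15 log units; within the scatter) stayed within the scatter, the corresponding step from compound 2 to compound 4 in this assay is expected to be of about the same small size, a 1.3-fold higher number from compound 2 to compound 4 (0.11 log units; within the scatter), resting on that single precedent. Compound 4 is therefore estimated to give about 3200 nM in this assay, expected to fall between 1600 nM and 6500 nM.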

Compound 4, concentration for total growth inhibition: 2960 nM
The estimate for compound 4 lay 1.1-fold (0.03 log units) above the measured number, within the range that was stated.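

In this assay the new step, a 1.2-fold higher number from compound 2 to compound 4 (0.08 log units; within the scatter), is small, and methoxy in place of hydrogen on an aromatic carbon gives steps that agree on the two cores: the same change on two cores in this assay, a 1.4-fold higher number (0.15 log units; within the scatter) from compound 1 to compound 3 and a 1.2-fold higher number (0.08 log units; within the scatter) from compound 2 to compound 4, 1.2-fold (0.08 log units) apart, within the scatter of two such steps. Across these two pairs, then, the change carried from one core to the other as a step within the scatter, even though the surroundings differ, with the entering methoxy in compound 4 ortho to a methoxy group and meta to a methoxy group. Among the compounds shown here, this shows only that the change left the number essentially where it was in both pairs; with two small steps it establishes no direction of effect, gives no reason for the agreement, and cannot say that the change would behave the same way on a further core.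

The compounds shown leave open whether a hydroxyl group, an ethoxy group or a chlorine atom entering in place of that hydrogen would leave the number just as unmoved. They also leave open whether a larger step would appear with a carboxylic acid on the same aromatic ring, since every step seen here involves methoxy alone.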